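The compounds below may be only part of what the source reports. "The series", "measured", "known", "first", "only" and "open" are said of these compounds alone.

Compound 1, `O=c1cc(Cn2cc(CCCCl)nn2)c2ccc(O)cc2o1`, gives 59800 nM in a functional assay on SW-620 cells (Homo sapiens) for inhibition, read by MTT assay, with a stated time of 72 h; on this read-out higher numbers stand for weaker inhibition and lower numbers for stronger inhibition.
Compound 3, `O=c1cc(Cn2cc(CCc3ccccc3)nn2)c2ccc(O)cc2o1`, gives 84400 nM in this assay.
Compound 2, `CC(C)(C)c1cn(Cc2cc(=O)oc3cc(O)ccc23)nn1`, reaches only the limit of this assay, > 100000 nM, and not a number.

Among the compounds with values here, compound 3 and compound 1 supply the only two numbers; the step of a 1.4-fold higher number from compound 1 to compound 3 (0.15 log units; within the scatter) lies within the scatter, so neither stands apart from the other. Compound 4, `O=c1cc(Cn2cc(-c3cc(F)cc(F)c3)nn2)c2ccc(O)cc2o1`, differs from compound 3 by 3,5-difluorophenyl in place of phenethyl on an aromatic carbon. The measured steps that bear on exchanging this group are an at least 1.1-fold lower number from compound 2 to compound 3 (0.07 log units; that floor lies within the scatter), a 1.4-fold higher number from compound 1 to compound 3 (0.15 log units; within the scatter) and an at least 1.6-fold higher number from compound 1 to compound 2 (0.22 log units; that floor lies within the scatter), none of them beyond the scatter, two of them resting on (the limit of > 100000 nM in this assay, at which 1 of the 3 values shown sits). No step beyond the scatter is therefore expected in this assay. Compound 4 is estimated at 75000 nM, between 28000 nM and 200000 nM, an expected step of a 1.1-fold lower number from compound 3 to compound 4 (0.05 log units; within the scatter).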

Compound 4, half-maximal inhibitory concentration: 66700 nM
Estimate against measurement, compound 4: 1.1-fold (0.05 log units) above, and the stated range covers the measured number.
By their numbers in this assay, from the lowest: compounds 1, 4 and 3 (each within the scatter of the next). At a limit, above all of these: compound 2.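

Exchanging phenethyl for 3,5-difluorophenyl on this aromatic carbon, which removes the chain between the two rings, changes little in this assay: a 1.3-fold lower number from compound 3 to compound 4 (0.10 log units; within the scatter). The same holds for 3,5-difluorophenyl in place of 3-chloropropyl, with a 1.1-fold higher number from compound 1 to compound 4 (0.05 log units; within the scatter), so a ring set directly on this carbon brings no step beyond the scatter. Against tert-butyl, only a floor can be read, an at least 1.4-fold lower number from compound 2 to compound 4 (0.17 log units; that floor lies within the scatter), and it rests on a limit: the limit of > 100000 nM in this assay, at which 1 of the 4 values shown sits.

From the compounds shown here alone, whether an amine, a carboxylic acid or a longer chain on this carbon would bring a step beyond the scatter remains open.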